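This account rests on a few compounds, and the source may have more. Where it says the series, first, only, none or still open, it means among the compounds named here.

Two close relatives of one shared core have been tested in a functional assay on CCRF-CEM cells (Homo sapiens) for cytotoxicity, read by MTT assay, with a stated time of 72 h; a lower number here means a stronger inhibitor of growth, a higher number a weaker inhibitor of growth. For the measured compounds named here, compound 1 `CSc1nc(NCCCc2ccccc2)c2ccccc2n1` is the first of them, and in this assay compound 1 gives 87800 nM. Compound 2 `CSc1nc(NCc2ccccc2)c2ccccc2n1` is the second. In this assay compound 2 shows only a limit, > 100000 nM, so no number is known for it. Compound 2 thus stands at the limit of > 100000 nM in this assay, at which 1 of the 2 values shown sits. Compound 3 `CSc1nc(NCCCCCO)c2ccccc2n1` is the next member of the series and is not yet measured; it differs from compound 2 by 4-hydroxybutyl in place of phenyl on a saturated chain carbon bound to a nitrogen on an aromatic ring. No measured step between two of these compounds is available, so the size of the change from compound 2 to compound 3 in this assay cannot be read from a neighbouring pair. Both measured compounds sit at or close to the weak end of what this assay can report, and compound 3 is expected to remain in that region, with the step that the limit leaves unreadable from compound 2 to compound 3 judged not to reach beyond the scatter. Compound 3 is therefore estimated at 110000 nM, within 50000 nM to 300000 nM, and a bare limit rather than a number is considered quite possible.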

Compound 3, concentration for total growth inhibition: > 100000 nM
Compound 3: a limit, no number (the forecaster's own chance of this, stated with the estimate: 65%); the middle value does not contradict the limit.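

With 4-hydroxybutyl in place of phenyl, this position now carries a chain with no ring and with a hydrogen-bond donor, yet in this assay compound 3 still gives only a limit, so the step from compound 2 cannot be read. For the compounds shown here, the one pair that can be read gives an at least 1.1-fold higher number from compound 1 to compound 3 (0.05 log units; that floor lies within the scatter), which establishes no real difference, although the limit leaves room for one. Exchanging the phenyl for this hydroxylated chain therefore brings no readable gain in growth inhibition, and the series gathers at the weak end of what the assay reports: the limit of > 100000 nM in this assay, at which 2 of the 3 values shown sit.

The compounds shown leave open how far compound 2 and compound 3 lie past their limits, and so whether the phenyl and the 4-hydroxybutyl differ at all. They also leave open whether an amine or a carboxylic acid at the end of the chain, or a longer chain, would bring a value clear of the limit.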